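The compounds below may be only part of what the source reports. "The series", "measured", "known", "first", "only" and "open" are said of these compounds alone.

Measured compounds:
compound 1 `CC(=O)N1CCC(c2ccc(-c3cc(C(=O)O)cc4cc(-c5ccc(C(F)(F)F)cc5)ccc34)cc2)CC1` — 92.4%
compound 2 `C#CCCCCN1CCC(c2ccc(-c3cc(C(=O)O)cc4cc(-c5ccc(C(F)(F)F)cc5)ccc34)cc2)CC1` — 9.6%

In a functional assay on the whole organism (strain ICR) for inhibition, with Mus musculus as the target, with stated times of 7 days and 3 h, at a dose of 10 umol/kg by the intraperitoneal route (a lower number here means less inhibition, a higher number more inhibition at the dose given (going by the name of the read-out)), compound 1 gives 92.4%, while compound 2 gives 9.6%, the lower of the two numbers, with compound 1 standing well beyond the scatter above it. Within the data shown here, the one measured step, a number 82.8 percentage points lower from compound 1 to compound 2 (beyond the scatter), is the only guide here. Compound 3 `CCC(=O)N1CCC(c2ccc(-c3cc(C(=O)O)cc4cc(-c5ccc(C(F)(F)F)cc5)ccc34)cc2)CC1` carries propanoyl in place of hex-5-yn-1-yl on an amine nitrogen in a ring. Since propanoyl resembles the acetyl of compound 1 far more than the hex-5-yn-1-yl of compound 2, the earlier large fall is expected to be largely reversed, giving an estimated step of a number 75.4 percentage points higher from compound 2 to compound 3 (beyond the scatter). Compound 3 is therefore estimated at 85%, within 60% to 98%.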

Compound 3, a percentage reported as inhibition, in the whole organism at one dose (the size of the read-out at that dose, not a potency): 55.7%
Compound 3: the middle estimate sits 29.3 percentage points above what was measured; the whole stated range lies above it.
By their numbers in this assay, from the lowest: compound 2; then compound 3; then compound 1.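

In this assay, a carbonyl on the amine nitrogen in a ring is not enough on its own to hold the high number: a number 46.1 percentage points higher from compound 2 to compound 3 (beyond the scatter), yet a number 36.7 percentage points lower from compound 1 to compound 3 (beyond the scatter). The change from acetyl to propanoyl, a single added methyl on the saturated chain carbon bound to the carbonyl carbon, therefore counts heavily at this position. Nothing available bears on the cause of either step.

The compounds shown leave open whether a longer acyl chain such as butanoyl would lower the number further, and how a benzoyl group on the same nitrogen would compare.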